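Bile acid receptor series: chloro to acetyl on the biaryl

The source may report more compounds than this note shows. Statements on the series, on what has been measured and on what is new or still open speak of the compounds shown alone.

Measured so far:
- compound 1 `COC(=O)/C=C/c1cccc(N(Cc2ccc(/C=C/c3c(C)cc(C)cc3C)cc2)C(=O)C(C)C)c1` — 149 nM
- compound 2 `COC(=O)/C=C/c1cccc(N(Cc2ccc(-c3cccc(Cl)c3)cc2)C(=O)C2CCCCC2)c1` — 94 nM
- compound 3 `COC/C=C/c1cccc(N(Cc2ccc(/C=C/C(=O)OC(C)(C)C)cc2)C(=O)C2CCCCC2)c1` — 243 nM

Three compounds sharing one core have been run in an assay on isolated protein with Bile acid receptor (Homo sapiens) as the target; a higher number here means that more compound is needed for the effect, a lower number that less compound is needed. Compound 2 gives the lowest of the three numbers, but the gap to compound 1 is within the scatter, so no order between those two can be read. The gap from compound 2 to compound 3 lies beyond the scatter; no single-point step between them is listed, so only the two values themselves are noted.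

Compound 4 `COC(=O)/C=C/c1cccc(N(Cc2ccc(-c3cccc(C(C)=O)c3)cc2)C(=O)C2CCCCC2)c1` has not yet been measured. It differs from compound 2 in one place: acetyl in place of chloro on an aromatic carbon. Going by the values given here, no measured pair shows this change, so the expectation rests on compound 2 alone.

With nothing in the data to point in either direction, the step from compound 2 to compound 4 is expected to be small, a 1.6-fold higher number from compound 2 to compound 4 (0.20 log units; within the scatter), likely not beyond the scatter, with a weak lean toward a higher number. Compound 4 is estimated at 150 nM in this assay, with a range from 50 nM to 450 nM.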

Compound 4, half-maximal effective concentration: 227 nM
Beside the measured number, compound 4's estimate is 1.5-fold (0.18 log units) below it; the range from low to high includes it.
By their numbers in this assay, from the lowest: compounds 2, 1, 4 and 3 (each within the scatter of the next, the first and the last beyond it).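

Going by these compounds alone, exchanging chloro for acetyl on this aromatic carbon gives in this assay the first step that can be tied to a single place: a 2.4-fold higher number from compound 2 to compound 4 (0.38 log units; beyond the scatter). Within the data shown here, the number at this position therefore responds to the group it carries, at least for the pair 3-chlorophenyl and 3-acetylphenyl, which the earlier compounds, differing from one another in several places, could not show. Nothing available explains why this change moves the number.

From the compounds shown here alone, whether the step is particular to acetyl or would also appear with an amine, a carboxylic acid or a nitrile on the same carbon remains open. Also open, going by these compounds, is how an unsubstituted phenyl would compare with both groups, and so whether chloro or acetyl moves the number from that baseline.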